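The source may hold more compounds than are shown below. What is called first, only, known or untested is meant among the compounds shown, and "the series" means these compounds.

In a functional assay on HCT-116 cells (Homo sapiens) for antiproliferative activity, read by MTT assay, with a stated time of 48 h (a higher number here means a weaker inhibitor, a lower number a stronger inhibitor), compound 1 `CCCCC(CCO)n1cnc2c(Cl)ncnc21` gives > 50000 nM, which is a limit of the assay and not a number. Within the data shown here, compound 2 `CCCCCCCCCC(CCO)n1cnc2c(Cl)ncnc21` gives 890 nM, the only true number so far. Compound 3 `CCCCCCCCCCCC(CCO)n1cnc2c(Cl)ncnc21` carries a longer chain: ethyl in place of hydrogen on a saturated chain carbon, ten or more bonds along the chain from an aromatic nitrogen. Among the measured compounds shown here, only one measured step bears on this, a pentyl in place of hydrogen on the same chain, and it is large and beyond the scatter: an at least 56-fold lower number from compound 1 to compound 2 (1.74 log units; beyond the scatter). That step points towards a lower number, so a smaller further fall is expected in this assay for this shorter extension, perhaps little beyond the scatter. The expected change is a 1.8-fold lower number from compound 2 to compound 3 (0.25 log units; within the scatter). For compound 3 the estimate is 500 nM, with an expected range of 150 nM to 1800 nM.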

Compound 3, half-maximal inhibitory concentration: 7590 nM
Compound 3: the middle estimate sits 15-fold (1.18 log units) below what was measured, outside the stated range (above it).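

In this assay lengthening the chain does not keep lowering the number: this ethyl gives an 8.5-fold higher number from compound 2 to compound 3 (0.93 log units; beyond the scatter), reversing the direction of the earlier pentyl step and leaving compound 2 with the lowest number of the three. The longest chain still stays on the better side of the shortest, with an at least 6.5-fold lower number from compound 1 to compound 3 (0.81 log units; beyond the scatter). That step starts from a limit and not a number: the limit of > 50000 nM in this assay, at which 1 of the 3 values shown sits.

Open, from the compounds shown here alone, is how the number runs for chain lengths between those of compound 2 and compound 3. Also open, going by these compounds, is whether an amine or a phenyl in place of the ethyl behaves as the ethyl does.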